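Replacing trifluoromethyl with an aminopiperidinylmethyl group: expected residence time

A few compounds are considered here, and "the series" means these few. Any claim that something is new, unique, unknown or untested is made for them only; others in the source may bear on it.

Of the compounds shown here, three sharing one amide-linked core have been measured in an ADME assay on the whole organism (Mus musculus, strain CD1), read by LC-MS, using cassette dosing, with a stated time of 24 h, at a dose of 0.4 mg/kg by the intravenous route; on this read-out higher numbers stand for a longer-lived compound and lower numbers for a shorter-lived compound. Compound 1 `Cc1cn(-c2cc(NC(=O)c3ccc(C)c(Nc4nccc(-c5ccccc5)n4)c3)cc(N3CCNCC3)c2)cn1` gives 1.19 h. Compound 2 `Cc1cn(-c2cc(CN3CCN(C)CC3)cc(NC(=O)c3ccc(C)c(Nc4nccc(-c5ccccc5)n4)c3)c2)cn1` gives 2.66 h. Within the data shown here, the only step between two measured compounds that differ in a single place is a 2.2-fold higher number from compound 1 to compound 2 (0.35 log units; beyond the scatter). Compound 3 `Cc1cn(-c2cc(NC(=O)c3ccc(C)c(Oc4ccccc4)c3)cc(C(F)(F)F)c2)cn1` gives 2.27 h; its number sits close to that of compound 2 and close to that of compound 1, and both of those gaps fall within the usual scatter, so no order among the three can be claimed from compound 3's position.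

Compound 4 `Cc1cn(-c2cc(CN3CCC[C@H](N)C3)cc(NC(=O)c3ccc(C)c(Oc4ccccc4)c3)c2)cn1` has not yet been measured in this assay. It differs from compound 3 in one place: (3-aminopiperidin-1-yl)methyl in place of trifluoromethyl on an aromatic carbon. Among the measured compounds shown here, no measured step swaps trifluoromethyl for this group. The nearest guide is the step from compound 1 to compound 2, where a methylene-linked cyclic amine replaced a directly attached one and the number rose modestly. That step concerns a different pair of groups, so it gives only a loose hint. The expected step is therefore a 1.2-fold lower number from compound 3 to compound 4 (0.08 log units; within the scatter), a change that is not expected to exceed the scatter. For compound 4 the estimated mean residence time is 1.9 h, with a range from 0.9 h to 4 h.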

Compound 4, mean residence time: 34.9 h
Beside the measured number, compound 4's estimate is 18-fold (1.26 log units) below it, outside the stated range (above it).
By their numbers in this assay, from the lowest: compounds 1, 3 and 2 (each within the scatter of the next, the first and the last beyond it); then compound 4.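

In this assay, the position meta to a 4-methyl-1H-imidazol-1-yl group proves highly sensitive to what is attached there: putting (3-aminopiperidin-1-yl)methyl in place of trifluoromethyl gives a 15-fold higher number from compound 3 to compound 4 (1.19 log units; beyond the scatter). Among these compounds, the only earlier step, a 2.2-fold higher number from compound 1 to compound 2 (0.35 log units; beyond the scatter), was modest and involved a different pair of groups, so it gave no sign that a single change at this position could have so large an effect. The swap alters several things at once, bringing in a six-membered non-aromatic ring, a hydrogen-bond donor and a defined stereocentre, and no measurement shown here explains the longer residence time.

The compounds shown leave open which part of the new group matters, since a piperidin-1-ylmethyl group without the amino substituent, or a simple aminomethyl group without the ring, would help separate the contribution of the ring from that of the amine. On these data alone, it also remains open whether the opposite configuration at the stereocentre, or the (4-methylpiperazin-1-yl)methyl group of compound 2 placed on the core of compound 4, would give a similarly long residence time.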